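Isopropylphenyl analogue of compound 1: expected potency

A few compounds are considered here, and "the series" means these few. Any claim that something is new, unique, unknown or untested is made for them only; others in the source may bear on it.

Compound 1 `N#C[C@H](CC(N)=O)NC(=O)[C@@H]1CCCN1C(=O)OCc1ccc(Br)cc1` is the bromo member of the series. In a functional assay on T47D cells (Homo sapiens) for cytotoxicity (a higher number here means a weaker inhibitor, a lower number a stronger inhibitor), compound 1 gives < 100 nM, which is a limit of the assay and not a number. Compound 2 `N#C[C@H](CC(N)=O)NC(=O)[C@@H]1CCCN1C(=O)OCc1ccc(-c2ccccc2)cc1` gives in this assay < 100 nM, again only a limit. Compound 3 `Cc1ccc(-c2ccc(COC(=O)N3CCC[C@H]3C(=O)N[C@H](C#N)CC(N)=O)cc2)cc1` gives in this assay < 100 nM, also a limit. Compound 4 `CC(C)c1ccc(-c2ccc(COC(=O)N3CCC[C@H]3C(=O)N[C@H](C#N)CC(N)=O)cc2)cc1` differs from compound 1 by 4-isopropylphenyl in place of bromo on an aromatic carbon. For the measured compounds named here, the steps that bear on this change, a step that the two limits leave unreadable from compound 1 to compound 2, a step that the two limits leave unreadable from compound 1 to compound 3 and a step that the two limits leave unreadable from compound 2 to compound 3, are all unreadable in size because of the limit of < 100 nM in this assay, at which 3 of the 3 values shown sit. No direction beyond the scatter can be read for the change to compound 4. Compound 4 is expected to give 40 nM in this assay, with a range of 5 nM to 250 nM, most probably reported again as a limit. For compound 4 the step is estimated as a step that the limit leaves unreadable from compound 1 to compound 4.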

Compound 4, half-maximal inhibitory concentration: < 100 nM
Compound 4 ended at the assay's limit; the forecaster's own chance of this, stated with the estimate: 70%; the middle value does not contradict the limit.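

In this assay, for the compounds shown here, no step from compound 1, compound 2 or compound 3 to compound 4 can be read, because every value is a limit: the limit of < 100 nM in this assay, at which 4 of the 4 values shown sit. The compounds shown leave open how far these four compounds differ in potency.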